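Methoxy for fluoro on the aryl of a shared core

This account rests on a few compounds, and the source may have more. Where it says the series, first, only, none or still open, it means among the compounds named here.

Compound 2 `Fc1cccc(-c2n[nH]cc2N2CCCNCC2)c1` stands at the edge of what an assay on isolated protein for binding affinity to 5-hydroxytryptamine receptor 4 (Homo sapiens) (a lower number here means a stronger inhibitor, a higher number a weaker inhibitor), can report: in this assay compound 2 gives > 10000 nM, which is a limit and not a number. Compound 1 `Cc1cccc(-c2n[nH]cc2N2CCCNCC2)c1` carries methyl in place of fluoro at the same aromatic carbon; in this assay compound 1 gives > 10000 nM, also a limit. The step that the two limits leave unreadable from compound 1 to compound 2 therefore cannot be read because of the limit of > 10000 nM in this assay, at which 2 of the 2 values shown sit.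

Compound 3 `COc1cccc(-c2n[nH]cc2N2CCCNCC2)c1` differs from compound 2 by methoxy in place of fluoro on an aromatic carbon. Going by the values given here, the only measured step is the unreadable one from methyl to fluoro, so no sized step bears on the move to methoxy, and nothing in the data argues for a change beyond the scatter or for a departure from the limit.

For compound 3 the estimate in this assay is 20000 nM, with a range from 5000 nM to 100000 nM. The step this expectation means is a step that the limit leaves unreadable from compound 2 to compound 3, and it is expected to remain unreadable at the limit.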

Compound 3, inhibition constant: > 10000 nM
Compound 3 ended at the assay's limit; the forecaster's own chance of this, stated with the estimate: 80%; the middle value is on the limit's open side.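

Going by these compounds alone, no step among compound 1, compound 2 and compound 3 can be read in this assay because all three values are limits: the limit of > 10000 nM in this assay, at which 3 of the 3 values shown sit.

The compounds shown leave open how methyl, fluoro and methoxy on the aromatic carbon compare in affinity beyond that limit.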